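Shifting the fluorine on the triazole-bound phenyl

A few compounds are considered here, and "the series" means these few. Any claim that something is new, unique, unknown or untested is made for them only; others in the source may bear on it.

Measured so far:
Compound 1, `CC1(C)[C@H]2CC[C@]1(C)N(Cc1cn(-c3ccccc3C#N)nn1)C(=O)C2`: 110 nM
Compound 2, `CC1(C)[C@H]2CC[C@]1(C)N(Cc1cn(-c3cccc(O)c3)nn1)C(=O)C2`: 370 nM
Compound 3, `CC1(C)[C@H]2CC[C@]1(C)N(Cc1cn(-c3cccc(F)c3)nn1)C(=O)C2`: 430 nM

All three share one core and differ only in the aryl group on the aromatic nitrogen of the triazole. In a functional assay on OVCAR-3 cells (Homo sapiens) for inhibition, read by MTT assay, with a stated time of 24 h (a higher number here means a weaker inhibitor, a lower number a stronger inhibitor), compound 1, bearing 2-cyanophenyl, gives the lowest number of the set. Compound 3 stands at the highest number; its nearest neighbour is compound 2, with a 1.2-fold higher number from compound 2 to compound 3 (0.07 log units; within the scatter), a gap within scatter, while its distance from compound 1 is a 3.9-fold higher number from compound 1 to compound 3 (0.59 log units; beyond the scatter).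

Compound 4, `CC1(C)[C@H]2CC[C@]1(C)N(Cc1cn(-c3ccccc3F)nn1)C(=O)C2`, is the next step from compound 3: 2-fluorophenyl in place of 3-fluorophenyl on an aromatic nitrogen. Among the measured compounds shown here, no measured pair exchanges fluoro between these two positions, so the nearest guide is a 3.9-fold higher number from compound 1 to compound 3 (0.59 log units; beyond the scatter), which shows that a group at the 2-position of the phenyl went with the lowest number, and a 3.4-fold higher number from compound 1 to compound 2 (0.53 log units; beyond the scatter), pointing the same way. Fluoro is not nitrile, so only part of that step is expected to be recovered. For compound 4 in this assay a modest lowering, a 1.7-fold lower number from compound 3 to compound 4 (0.24 log units; within the scatter), is expected, giving an estimate of 250 nM with a range of 120 nM to 520 nM.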

Compound 4, half-maximal inhibitory concentration: 300 nM
Beside the measured number, compound 4's estimate is 1.2-fold (0.08 log units) below it; measured number inside the range.
By their numbers in this assay, from the lowest: compound 1; then compounds 4, 2 and 3 (each within the scatter of the next).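

Exchanging 3-fluorophenyl for 2-fluorophenyl gives a 1.4-fold lower number from compound 3 to compound 4 (0.16 log units; within the scatter) in this assay, so this read-out does not separate the two fluorine placings, and a 1.2-fold lower number from compound 2 to compound 4 (0.09 log units; within the scatter) likewise leaves compound 4 level with the 3-hydroxyphenyl compound. Among the compounds shown here, the one step beyond the scatter is a 2.7-fold higher number from compound 1 to compound 4 (0.44 log units; beyond the scatter) with fluoro in place of cyano on the same aromatic carbon, which ties the lower number of compound 1 to the nitrile and not simply to having a group at that carbon. No measurement at hand offers an explanation for either result.

Still open, going by these compounds, is whether another group on that aromatic carbon, such as an amine, a carboxylic acid or a methoxy group, would track the nitrile or the fluoro. The compounds shown also leave open whether the nitrile step holds with the aryl group kept and the shared core changed.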